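The source may report more compounds than this note shows. Statements on the series, on what has been measured and on what is new or still open speak of the compounds shown alone.

Measured compounds and their largest responses:

Compound 1, `CC(C)(Oc1ccc(NCc2cccc(Oc3ccccc3)c2)cc1)C(=O)O`: 14%
Compound 2, `O=C(O)CSc1ccc(NCc2cccc(Oc3ccccc3)c2)cc1`: 84%
Compound 3, `CC(CC(=O)O)c1ccc(NCc2cccc(Oc3ccccc3)c2)cc1`: 83%

In a functional assay on CHO cells for agonist activity at Free fatty acid receptor 1 (Homo sapiens), read by a luciferase reporter (a higher number here means a larger maximal response, a lower number a smaller maximal response), compound 3 stands second highest of the three numbers. Its nearest neighbour is compound 2, and the gap between them, a number 1 percentage points lower from compound 2 to compound 3 (within the scatter), lies within the scatter, so the two cannot be told apart. Compound 1 lies far below, as the step of a number 69 percentage points higher from compound 1 to compound 3 (beyond the scatter) shows.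

Compound 4, `CN(C)C(=O)CCc1ccc(NCc2cccc(Oc3ccccc3)c2)cc1`, is not yet measured. It differs from compound 3 in one place: 2-(dimethylcarbamoyl)ethyl in place of 1-(carboxymethyl)ethyl on an aromatic carbon.

The measured steps that touch this position, a number 70 percentage points higher from compound 1 to compound 2 (beyond the scatter) and a number 69 percentage points higher from compound 1 to compound 3 (beyond the scatter), are large, but in each of them a 1-carboxy-1-methylethoxy, (carboxymethyl)sulfanyl or 1-(carboxymethyl)ethyl group is kept; none of them exchanges such a group for a 2-(dimethylcarbamoyl)ethyl group. The direction of the step to compound 4 is therefore not covered by any measured pair, and the expectation rests on the fact that the group which leaves is shared by all three measured compounds, including compound 2 and compound 3.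

Compound 4 is expected to give 25%, within 5% to 60%. This estimate means a step of a number 58 percentage points lower from compound 3 to compound 4 (beyond the scatter), a drop beyond the scatter, though with wide uncertainty.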

Compound 4, largest response reached (reported as percent of maximum), in percent of the reference or control that the assay uses: 50%
Compound 4: middle estimate off by 25 percentage points, on the low side; measured number inside the range.
By their numbers in this assay, from the lowest: compound 1; then compound 4; then compounds 3 and 2 (each within the scatter of the next).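

Within the data shown here, compound 4 is the first compound here whose group at this place carries no carboxylic acid, and in this assay a clear response remains, although it falls short of the two acids with the highest numbers (a number 33 percentage points lower from compound 3 to compound 4 (beyond the scatter); a number 34 percentage points lower from compound 2 to compound 4 (beyond the scatter)). A carboxylic acid is therefore not needed for a response in this series, yet having one does not guarantee a large response: compound 1 has one, and the 2-(dimethylcarbamoyl)ethyl group still outperforms its 1-carboxy-1-methylethoxy group (a number 36 percentage points higher from compound 1 to compound 4 (beyond the scatter)). Nothing available explains these differences.

The compounds shown leave open how a methyl ester, a tetrazole or an amide that keeps the amide hydrogen would behave at this place. They also cannot separate the effect of losing the acid from that of the other differences between these chains.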